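The source may report more compounds than this note shows. Statements on the series, on what has been measured and on what is new or still open speak of the compounds shown alone.

In a toxicity assay on cells (Macrophage, Mus musculus, strain BALB/c) for cytotoxicity, read by MTT assay (a higher number here means a weaker inhibitor, a lower number a stronger inhibitor), three compounds on a shared core read alike: compound 1 `C=CCOc1cc(OC)c(C(=O)/C=C/Cc2ccccc2)c(OCC=C)c1` gives 14800 nM, compound 2 `C=CCOc1cc(OC)c(C(=O)/C=C/c2ccc(F)cc2)c(OCC=C)c1` gives 13800 nM, and compound 3 `C=CCOc1cc(OC)c(C(=O)/C=C/c2cccc(OC)c2)c(OCC=C)c1` gives 13100 nM. Compound 3 thus stands level with the other two, within the scatter. Compound 4 `C=CCOc1cc(OC)c(C(=O)/C=C/c2ccccc2Br)c(OCC=C)c1` has 2-bromophenyl in place of 3-methoxyphenyl on a double-bonded chain carbon bound to a double-bonded chain carbon. Three measured steps at this same place bear on it: a 1.1-fold lower number from compound 1 to compound 2 (0.03 log units; within the scatter), a 1.1-fold lower number from compound 1 to compound 3 (0.05 log units; within the scatter) and a 1.1-fold lower number from compound 2 to compound 3 (0.02 log units; within the scatter). All stayed within the scatter, though none involved 2-bromophenyl. No step beyond the scatter is therefore expected in this assay, and the estimated change is a 1.0-fold lower number from compound 3 to compound 4 (0.00 log units; within the scatter). The expected value for compound 4 is 13000 nM, within an estimated range of 7500 nM to 20000 nM.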

Compound 4, half-maximal inhibitory concentration: 5400 nM
The estimate for compound 4 lay 2.4-fold (0.38 log units) above the measured number, outside the stated range (below it).
By their numbers in this assay, from the lowest: compound 4; then compounds 3, 2 and 1 (each within the scatter of the next).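

In this assay this place, on a double-bonded chain carbon bound to a double-bonded chain carbon, had looked unresponsive, yet 2-bromophenyl gives steps beyond the scatter: a 2.4-fold lower number from compound 3 to compound 4 (0.38 log units; beyond the scatter), a 2.6-fold lower number from compound 2 to compound 4 (0.41 log units; beyond the scatter) and a 2.7-fold lower number from compound 1 to compound 4 (0.44 log units; beyond the scatter). Benzyl, 4-fluorophenyl and 3-methoxyphenyl read alike, so among these four compounds only 2-bromophenyl sets a compound apart. Nothing at hand accounts for this shift. Going by these compounds, whether the step belongs to the bromine or to where it sits on the phenyl remains open. So does whether 4-bromophenyl or 2-chlorophenyl at this place would read like compound 4.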